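Series notes: methoxy in place of hydrogen, compound 4

The compounds below may be only part of what the source reports. "The series", "measured", "known", "first", "only" and "open" are said of these compounds alone.

Three compounds of the shared core carry a number in a functional assay on MCF7 cells (Homo sapiens) for cytotoxicity, read by MTT assay, with a stated time of 2 days, tested at 100 uM; on this read-out lower numbers stand for a stronger effect and higher numbers for a weaker effect at the one concentration tested. Compound 1 `COc1ccc(-c2cc(C(C)=O)c3[nH]c(-c4ccc(OC)cc4)cc3c2)cc1` gives 39.9%. Compound 2 `CC(=O)c1cc(/C=C/c2ccccc2)cc2cc(-c3ccccc3)[nH]c12` gives 34.1%. Compound 3 `CC(=O)c1cc(/C=C/c2ccc(F)cc2)cc2cc(-c3ccccc3)[nH]c12` gives 46.7%. For the measured compounds named here, compound 3 holds the highest of the three numbers; the nearest is compound 1, a gap within the scatter, and the one step recorded within the set, a number 12.6 percentage points higher from compound 2 to compound 3 (beyond the scatter), is modest but beyond the scatter.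

Compound 4 `COc1ccc(-c2cc3cc(/C=C/c4ccc(F)cc4)cc(C(C)=O)c3[nH]2)cc1` is not yet measured. Its change from compound 3 is methoxy in place of hydrogen on an aromatic carbon, sitting on an aromatic carbon of a six-membered aromatic ring of carbon only, para to a large group; cut one bond further out, it reads phenyl to 4-methoxyphenyl. Going by the values given here, no measured pair covers this exact change. The step from compound 2 to compound 3 concerns fluoro, not methoxy, and says nothing direct about it. What can be drawn on is compound 1, which carries methoxy groups and in this assay sits within the scatter of compound 3. On that basis no step beyond the scatter is expected from compound 3 to compound 4: a number 2.7 percentage points lower from compound 3 to compound 4 (within the scatter). Compound 4 is estimated at 44%, with a range from 30% to 60%.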

Compound 4, a percentage reported as activity, at one concentration (the size of the read-out at that concentration, not a potency): 47.6%
Estimate against measurement, compound 4: 3.6 percentage points below; the measured number falls inside the stated range.
By their numbers in this assay, from the lowest: compounds 2, 1, 3 and 4 (each within the scatter of the next, the first and the last beyond it).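

In this assay, for the compounds shown here, the pair of compound 3 and compound 4 gives the first direct reading of methoxy in place of hydrogen on an aromatic carbon, para to a large group (a number 0.9 percentage points higher from compound 3 to compound 4 (within the scatter)), so with the 2-(4-fluorophenyl)ethenyl group held fixed, the change from phenyl to 4-methoxyphenyl leaves the read-out within the scatter. The second new pair reads a different place on the shared core, where 2-(4-fluorophenyl)ethenyl stands in place of 4-methoxyphenyl on an aromatic carbon (a number 7.7 percentage points higher from compound 1 to compound 4 (within the scatter)), and this exchange also stays within the scatter in this single-concentration read-out. No available evidence bears on why either change leaves the number within the scatter.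

Still open, going by these compounds, is whether an amine, a carboxylic acid or a longer chain on the oxygen at this position would move the number beyond the scatter, and whether methoxy would read the same on the unfluorinated compound 2. With one cell line at one concentration, the compounds shown also give no potency for any member of the series and no reading of the same changes in other cells.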